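Carbamate aryl swap on the shared core

The source may report more compounds than this note shows. Statements on the series, on what has been measured and on what is new or still open speak of the compounds shown alone.

Compound 3 `CC(C)=CCC1Cc2c(OC(=O)Nc3ccc(F)cc3F)cc(=O)n(CCCO)c2CC1(C)C` stands highest of the three numbers in a functional assay on PANC-1 cells (Homo sapiens) for inhibition, read by MTT assay, with a stated time of 24 h, tested at 10 uM (a lower number here means less inhibition, a higher number more inhibition at the concentration tested (going by the name of the read-out)), where compound 3 gives 69.7%. Compound 1 `CCOc1cc(=O)n(CCCO)c2c1CC(CC=C(C)C)C(C)(C)C2` gives 66.5%, a gap within the scatter, while compound 2 `CC(C)=CCOc1cc(=O)n(CCCO)c2c1CC(CC=C(C)C)C(C)(C)C2` gives 20.7%, so that only a number 49 percentage points higher from compound 2 to compound 3 (beyond the scatter) is a large step. The change to compound 4 `CC(C)=CCC1Cc2c(OC(=O)Nc3ccc(F)c(Cl)c3)cc(=O)n(CCCO)c2CC1(C)C` is 3-chloro-4-fluorophenyl in place of 2,4-difluorophenyl on an amide-type nitrogen. Within the data shown here, none of the measured steps touches the group on the amide-type nitrogen: a number 45.8 percentage points lower from compound 1 to compound 2 (beyond the scatter) and a number 3.2 percentage points higher from compound 1 to compound 3 (within the scatter) both concern the oxygen on the aromatic ring. Among the measured compounds shown here, with no step bearing on this change, nothing beyond the scatter is expected in this assay. Compound 4 is therefore estimated at 68% with a range of 50% to 82%. The expected step is a number 1.7 percentage points lower from compound 3 to compound 4 (within the scatter).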

Compound 4, a percentage reported as inhibition, at one concentration (the size of the read-out at that concentration, not a potency): 79.8%
Estimate against measurement, compound 4: 11.8 percentage points below; measured number inside the range.
By their numbers in this assay, from the lowest: compound 2; then compounds 1 and 3 (each within the scatter of the next); then compound 4.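

In this assay the group on the amide-type nitrogen turns out to count: 3-chloro-4-fluorophenyl in place of 2,4-difluorophenyl gives a number 10.1 percentage points higher from compound 3 to compound 4 (beyond the scatter) as a modest step. The new carbamoyl group also separates from ethyl on the oxygen, with a number 13.3 percentage points higher from compound 1 to compound 4 (beyond the scatter) where the 2,4-difluorophenyl carbamoyl did not, and its gap to 3-methylbut-2-en-1-yl grows to a number 59.1 percentage points higher from compound 2 to compound 4 (beyond the scatter) in a large step. Nothing at hand accounts for these steps.

Which part of the aryl change carries the step stays open. So does how 3,4-dichlorophenyl or 4-methoxyphenyl on the amide-type nitrogen would read.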